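This account rests on a few compounds, and the source may have more. Where it says the series, first, only, none or still open, it means among the compounds named here.

Measured compounds:
Compound 1 `CCOCOCc1ccc(-c2cncc(Cl)c2N2CCC3(CCNC3=O)CC2)o1` gives 2970 nM in a functional assay on MV4-11 cells (Homo sapiens) for inhibition, read by resazurin assay, with a stated time of 72 h; on this read-out higher numbers stand for weaker inhibition of growth and lower numbers for stronger inhibition of growth.
Compound 2 `Cc1ccsc1-c1cncc(Cl)c1N1CCC2(CCNC2=O)CC1` gives 910 nM in this assay.
Compound 3 `O=C1NCCC12CCN(c1c(Cl)cncc1-c1ccc(CN3CCCCC3)s1)CC2` gives 4010 nM in this assay.

Among these three, compound 2 has the lowest number; compound 1 and compound 3 both sit beyond the scatter above it, so compound 2 stands as the most potent of the set. The unmeasured compound 4 `O=Cc1sccc1-c1cncc(Cl)c1N1CCC2(CCNC2=O)CC1` differs from compound 2 in one place: 2-formylthiophen-3-yl in place of 3-methylthiophen-2-yl on an aromatic carbon. Going by the values given here, no step between two measured compounds reports this kind of change, so nothing calibrates it. Since the two larger substituted rings of compound 1 and compound 3 give weaker growth inhibition than compound 2, a modest weakening is expected for compound 4 in this assay, of the size a 1.8-fold higher number from compound 2 to compound 4 (0.25 log units; within the scatter). Compound 4 is therefore estimated at 1600 nM, within 500 nM to 5000 nM.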

Compound 4, concentration for 50% growth inhibition: 28700 nM
Compound 4: the middle estimate sits 18-fold (1.25 log units) below what was measured, outside the stated range (above it).
By their numbers in this assay, from the lowest: compound 2; then compounds 1 and 3 (each within the scatter of the next); then compound 4.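

At the aromatic carbon ortho to a large group, replacing 3-methylthiophen-2-yl with 2-formylthiophen-3-yl is far from neutral: in this assay it gives a 32-fold higher number from compound 2 to compound 4 (1.50 log units; beyond the scatter). Going by these compounds alone, this is the first single-place step in the set, and it shows that growth inhibition is highly sensitive to the change at this position. No measurement here accounts for the loss.

The step changes the thiophene attachment and replaces methyl with formyl together, so their contributions remain unseparated. Going by these compounds, whether a hydroxymethyl group or an amine in place of the formyl would restore growth inhibition also stays open.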